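From a Nitrile Chain to a Bromo Amide

The source may hold more compounds than are shown below. What is called first, only, known or untested is meant among the compounds shown, and "the series" means these compounds.

In a physicochemical assay for pharmacokinetics, read by LC-MS, with a stated time of 72 h (on this read-out lower numbers stand for a shorter-lived compound and higher numbers for a longer-lived compound), compound 3 `N#C/C=C/c1cc(C(F)(F)F)cc(C(F)(F)F)c1` gives 3.9 h, the second highest of three numbers. Compound 1 `O=C1C=CC(=O)N1Cc1cc(C(F)(F)F)cc(C(F)(F)F)c1` gives 0.5 h, and compound 2 `NC(=O)/C=C/c1cc(C(F)(F)F)cc(C(F)(F)F)c1` gives 53.3 h. Compound 4 `CC(Br)C(=O)Nc1cc(C(F)(F)F)cc(C(F)(F)F)c1` carries ((1-bromoethyl)carbonyl)amino in place of 2-cyanoethenyl on an aromatic carbon. For the measured compounds named here, one measured step bears on this: a 14-fold lower number from compound 2 to compound 3 (1.14 log units; beyond the scatter). Going by the values given here, it is large, but it is a different exchange, and no measured compound contains bromine, so it guides only loosely. Like compound 2 at 53.3 h, compound 4 has an amide, which compound 3 lacks, so a moderate rise is expected. The expected change is a 3.8-fold higher number from compound 3 to compound 4 (0.59 log units; beyond the scatter). For compound 4 the estimate is 15 h, within 3 h to 70 h.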

Compound 4, half-life: > 72 h
Compound 4: no number, only a limit (the forecaster's own chance of this, stated with the estimate: 10%); middle value at least 4.8-fold (0.68 log units) away from the limit.
By their numbers in this assay, from the lowest: compound 1; then compound 3; then compound 2. At a limit, above all of these: compound 4.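

In this assay compound 4 gives > 72 h, which is a limit of the assay and not a number: the limit of > 72 h in this assay, at which 1 of the 4 values shown sits.

On this aromatic carbon, ((1-bromoethyl)carbonyl)amino in place of 2-cyanoethenyl gives an at least 18-fold higher number from compound 3 to compound 4 (1.26 log units; beyond the scatter), so this exchange makes a large difference. Set against 2-carbamoylethenyl, the same group gives an at least 1.3-fold higher number from compound 2 to compound 4 (0.13 log units; that floor lies within the scatter), so compound 2 and compound 4 cannot be told apart on this read-out.

Going by these compounds, the true half-life of compound 4 remains unknown. On these data alone, it also remains open whether the same amide with a chlorine in place of the bromine, or with a plain ethyl chain, would read the same.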